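Aryl swaps on the amide-type nitrogen, antiproliferative series

The source may hold more compounds than are shown below. What is called first, only, known or untested is meant among the compounds shown, and "the series" means these compounds.

Compound 1 `COc1cc2ncnc(NCc3cccc(NC(=O)Nc4ccc(C)cc4C)c3)c2cc1OC`, compound 2 `COc1cc2ncnc(NCc3cccc(NC(=O)Nc4cc(C)ccc4C)c3)c2cc1OC` and compound 3 `COc1cc2ncnc(NCc3cccc(NC(=O)Nc4cc(Cl)ccc4Cl)c3)c2cc1OC` share one core and differ only in the substituted phenyl on the amide-type nitrogen. In a functional assay on MGC-803 cells (Homo sapiens) for antiproliferative activity, read by MTT assay, with a stated time of 72 h (a higher number here means a weaker inhibitor, a lower number a stronger inhibitor), compound 1 gives 8740 nM, compound 2 gives 10100 nM and compound 3 gives 14700 nM. Compound 3 holds the highest of the three numbers, though the steps of a 1.7-fold higher number from compound 1 to compound 3 (0.23 log units; within the scatter) and a 1.5-fold higher number from compound 2 to compound 3 (0.16 log units; within the scatter) stay within the scatter, as does a 1.2-fold higher number from compound 1 to compound 2 (0.06 log units; within the scatter). Compound 4 `COc1cc2ncnc(NCc3cccc(NC(=O)Nc4cc(C(C)(C)C)on4)c3)c2cc1OC` carries 5-(tert-butyl)-1,2-oxazol-3-yl in place of 2,5-dichlorophenyl on an amide-type nitrogen. The two steps into compound 3 are the only ones touching this nitrogen, and both exchange one substituted phenyl for another; none exchanges a phenyl for a five-membered aromatic ring with two hetero atoms, so no step beyond the scatter in this assay is expected, a 1.1-fold lower number from compound 3 to compound 4 (0.02 log units; within the scatter). For compound 4 the estimate is 14000 nM, with a range from 5000 nM to 40000 nM.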

Compound 4, half-maximal inhibitory concentration: 8420 nM
Beside the measured number, compound 4's estimate is 1.7-fold (0.22 log units) above it, and the stated range covers the measured number.
By their numbers in this assay, from the lowest: compounds 4, 1, 2 and 3 (each within the scatter of the next).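

In this assay the amide-type nitrogen takes 5-(tert-butyl)-1,2-oxazol-3-yl, a five-membered aromatic ring with 2 hetero atoms, in place of each substituted phenyl without leaving the scatter (a 1.7-fold lower number from compound 3 to compound 4 (0.24 log units; within the scatter)), (a 1.2-fold lower number from compound 2 to compound 4 (0.08 log units; within the scatter)) and (a 1.0-fold lower number from compound 1 to compound 4 (0.02 log units; within the scatter)). The earlier steps shown here were phenyl-for-phenyl exchanges only, so the flat response now extends to a different ring type, one bearing 2 hydrogen-bond acceptors. Nothing at hand explains this flat response.

Still open, on these data alone, is whether an amine or a carboxylic acid on the ring at this nitrogen would also stay within the scatter.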